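Swapping the Aryl Group on Compound 2

This account rests on a few compounds, and the source may have more. Where it says the series, first, only, none or still open, it means among the compounds named here.

- compound 1 `Cc1nc(N2CCN(C)CC2)c2nc(-c3ccccc3Cl)n(CCO)c2n1`: 99%
- compound 2 `Cc1nc(N2CCN(C)CC2)c2nc(-c3cccc(C(F)(F)F)c3)n(C3CCOCC3)c2n1`: 44%

These two compounds were tested in an ADME assay (liver) for metabolic stability, with Liver microsome (Canis lupus familiaris) as the target, read by LC-MS, using microsomes, with a stated time of 30 min, tested at 4 uM; a higher number here means that more of the compound is left, a lower number that less of the compound is left. Compound 2 holds the lower of the two numbers at 44%, a gap beyond the scatter from compound 1. Compound 3 `Cc1nc(N2CCN(C)CC2)c2nc(-c3ccccc3C#N)n(C3CCOCC3)c2n1` has not been measured yet. It keeps the oxan-4-yl group of compound 2 and carries 2-cyanophenyl in place of 3-(trifluoromethyl)phenyl on an aromatic carbon. Among the compounds with values here, no two measured compounds differ in one place only, so no measured step shows what such a swap does. Within the data shown here, the only guide to direction is compound 1 at 99%, which differs from compound 2 in more than one place. A moderate upward move is therefore expected, with an estimated step of a number 14 percentage points higher from compound 2 to compound 3 (beyond the scatter). For compound 3 the estimate is 58%, with an expected range from 35% to 80%.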

Compound 3, percent of the compound remaining: 11%
Compound 3: the middle estimate sits 47 percentage points above what was measured; the whole stated range lies above it.
By their numbers in this assay, from the lowest: compound 3; then compound 2; then compound 1.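

In this assay, the group on the aromatic carbon between two ring nitrogen atoms proves able to shift the result by itself. Within the data shown here, with the oxan-4-yl group and the rest of the core held constant, putting 2-cyanophenyl in place of 3-(trifluoromethyl)phenyl gives a large step, a number 33 percentage points lower from compound 2 to compound 3 (beyond the scatter), and this is the first change in a single place. Nothing available explains why this swap leaves less of the compound intact.

Still open, as far as these compounds go, is whether the nitrile itself or its place on the phenyl ring drives this step; a 3-cyanophenyl or a plain phenyl group on the same core would help to separate the two. From the compounds shown here alone, it is also open whether the step would keep its size with the side chain of compound 1 in place of oxan-4-yl.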